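The source may hold more compounds than are shown below. What is called first, only, known or untested is meant among the compounds shown, and "the series" means these compounds.

Measured compounds:
compound 1 `COc1cc(C2=NN(C(C)=O)C(c3ccc(Cl)c(Cl)c3)O2)cc(OC)c1OC`, 28.1%
compound 2 `COc1cc(C(=O)N/N=C/c2ccc(Cl)c([N+](=O)[O-])c2)cc(OC)c1OC`, 32.1%
compound 3 `COc1cc(C2=NN(C(C)=O)C(c3ccc(Cl)c([N+](=O)[O-])c3)O2)cc(OC)c1OC`, 43.3%

In a functional assay on PC-3 cells (Homo sapiens) for antiproliferative activity, read by MTT assay, tested at 1 uM (on this read-out lower numbers stand for a weaker effect and higher numbers for a stronger effect at the one concentration tested), compound 3 gives 43.3%, and compound 1 gives 28.1%. The two share a core and differ only by chloro in place of nitro on an aromatic carbon; this change made the step of a number 15.2 percentage points lower from compound 3 to compound 1 (beyond the scatter). Compound 2 gives 32.1% in this assay. Compound 2 is built on a different core from compound 3, and the difference between the two cores is not broken down here. Compound 4 `COc1cc(C(=O)N/N=C/c2ccc(Cl)c(Cl)c2)cc(OC)c1OC` has not yet been measured. It differs from compound 2 by chloro in place of nitro on an aromatic carbon, the same change as that from compound 3 to compound 1, at a place described in the same words. In this assay, for the measured compounds named here, the step from compound 2 to compound 4 is therefore expected to be a number 12.1 percentage points lower from compound 2 to compound 4 (beyond the scatter), set beside a number 15.2 percentage points lower from compound 3 to compound 1 (beyond the scatter), because the only measured example of this change, a number 15.2 percentage points lower from compound 3 to compound 1 (beyond the scatter), went downward. This rests on a single pair on another core, so the range is kept wide. Compound 4 is expected to give 20%, between 8% and 34%.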

Compound 4, a percentage reported as inhibition, at one concentration (the size of the read-out at that concentration, not a potency): 13.5%
Estimate against measurement, compound 4: 6.5 percentage points above, and the stated range covers the measured number.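

Moved to a second core, chloro in place of nitro on an aromatic carbon gave a number 18.6 percentage points lower from compound 2 to compound 4 (beyond the scatter) in this assay. The change therefore carried over between these two cores in direction, and the two steps do not differ in size: the same change on two cores in this assay, a number 15.2 percentage points lower (beyond the scatter) from compound 3 to compound 1 and a number 18.6 percentage points lower (beyond the scatter) from compound 2 to compound 4, 3.4 percentage points apart, within the scatter of two such steps This rests on just two pairs, with the change at one place and read at a single concentration, so it does not show that the step would hold on any further core, and it gives no reason for the fall.

The compounds shown leave open whether an amine, a nitrile or a carboxylic acid at the same place would fit the picture on either core, since only nitro and chloro appear there. As far as these compounds go, it also remains open whether the step would keep its size at other concentrations or in other cell lines.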